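A side-group exchange on the shared core

A few compounds are considered here, and "the series" means these few. Any claim that something is new, unique, unknown or untested is made for them only; others in the source may bear on it.

Compound 1 `CC(C)=CCC[C@]1(C)/C=C/[C@@H](OC(=O)C=C(C)C)[C@](C)(O)/C=C/C(=O)/C(CN(C)C)=C\C1` - 590 nM
Compound 2 `CC(C)=CCC[C@]1(C)/C=C/[C@@H](OC(=O)C=C(C)C)[C@](C)(O)/C=C/C(=O)/C(COC(=O)c2ccc([N+](=O)[O-])cc2)=C\C1` - 1310 nM

Within the data shown here, in a functional assay on A549 cells (Homo sapiens) for antiproliferative activity, read by MTT assay, with a stated time of 48 h (a higher number here means a weaker inhibitor, a lower number a stronger inhibitor), compound 2 stands at 1310 nM, the higher of the two numbers measured so far. Compound 3 `CC(C)=CCC[C@]1(C)/C=C/[C@@H](OC(=O)C=C(C)C)[C@](C)(O)/C=C/C(=O)/C(Cn2cc(CO)nn2)=C\C1` differs from it as follows: 4-(hydroxymethyl)-1H-1,2,3-triazol-1-yl in place of ((4-nitrophenyl)carbonyl)oxy on a saturated chain carbon bound to a double-bonded ring carbon. Among the measured compounds shown here, only one measured step touches this place, a 2.2-fold higher number from compound 1 to compound 2 (0.35 log units; beyond the scatter), and it was modest. For the measured compounds named here, no measured compound carries the entering group, so only a small shift toward a lower number is expected, perhaps none beyond the scatter. For compound 3 the estimated step is a 1.3-fold lower number from compound 2 to compound 3 (0.12 log units; within the scatter). Compound 3 is expected at 1000 nM, with an estimated range of 400 nM to 2800 nM.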

Compound 3, half-maximal inhibitory concentration: 3470 nM
Estimate against measurement, compound 3: 3.5-fold (0.54 log units) below, and the stated range ends below it.
By their numbers in this assay, from the lowest: compound 1; then compound 2; then compound 3.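

In this assay, replacing the ester at this place with the triazole raises the number further, a 2.6-fold higher number from compound 2 to compound 3 (0.42 log units; beyond the scatter), and the gap to the amine is larger still, a 5.9-fold higher number from compound 1 to compound 3 (0.77 log units; beyond the scatter). The entering 4-(hydroxymethyl)-1H-1,2,3-triazol-1-yl has fewer heavy atoms than the ((4-nitrophenyl)carbonyl)oxy it replaces, yet compound 3 has the highest number of the three. Nothing given here explains this order.

From the compounds shown here alone, whether a cyclic amine such as morpholine or pyrrolidine would stay close to compound 1 remains open. So does the role of the hydroxymethyl on the triazole.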